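From Iodo to Ethoxy on the Shared Core

A few compounds are considered here, and "the series" means these few. Any claim that something is new, unique, unknown or untested is made for them only; others in the source may bear on it.

Among the compounds with values here, in an ADME assay on CCRF-CEM cells (Homo sapiens) for antiproliferative activity, with a stated time of 48 h (a lower number here means a stronger inhibitor, a higher number a weaker inhibitor), compound 1 (`Nc1ccc(/C=C/C(=O)c2ccc(Cl)cc2)cc1`) gives 21000 nM and compound 2 (`Nc1ccc(/C=C/C(=O)c2ccc(I)cc2)cc1`) gives 16000 nM, so compound 2 stands within the scatter of the only other measured compound. Compound 3 (`CCOc1ccc(C(=O)/C=C/c2ccc(N)cc2)cc1`) carries ethoxy in place of iodo on an aromatic carbon, para to a large group (ethoxy in place of iodo on an aromatic carbon). Within the data shown here, the one measured step, a 1.3-fold lower number from compound 1 to compound 2 (0.12 log units; within the scatter), lies within the scatter. Among the measured compounds shown here, no measured compound carries ethoxy, so this guide is thin, and no step beyond the scatter is expected in this assay in either direction. Compound 3 is expected at 15000 nM, with 6000 nM to 40000 nM as its estimated range.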

Compound 3, half-maximal inhibitory concentration: 15000 nM
The estimate for compound 3 equals the measured number at the digits printed, and the stated range covers the measured number.
By their numbers in this assay, from the lowest: compounds 3, 2 and 1 (each within the scatter of the next).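

In this assay both a 1.1-fold lower number from compound 2 to compound 3 (0.03 log units; within the scatter) and a 1.4-fold lower number from compound 1 to compound 3 (0.15 log units; within the scatter) lie within the scatter, so on this aromatic carbon, para to a large group, ethoxy cannot be told apart from iodo or chloro. The exchange of iodo, with 1 heavy atom and 0 hydrogen-bond acceptors, for ethoxy, with 3 heavy atoms and 1 hydrogen-bond acceptor, brings no step beyond the scatter. No evidence bears on this result. Going by these compounds, whether an amine, a carboxylic acid or a longer chain at this position would give a step beyond the scatter remains open.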